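A Four-Membered Ring in Place of Phenyl: Expected Dose

The compounds below may be only part of what the source reports. "The series", "measured", "known", "first", "only" and "open" are said of these compounds alone.

Of the compounds shown here, three have been tested in a functional assay on the whole organism (Hindlimb, strain albino) with Mus musculus as the target, in the maximal electroshock model, with a stated time of 0.5 h; a higher number here means that more compound is needed for the effect, a lower number that less compound is needed. Compound 2 `O=C(/C=C/c1ccccc1)Nc1nc2ccc([N+](=O)[O-])cc2s1` gives 485 umol/kg. Compound 1 `O=C(/C=C/OC1=CC=C1)Nc1nc2ccc([N+](=O)[O-])cc2s1` gives in this assay 597 umol/kg; the change from compound 2 to compound 1 is a group of 5 heavy atoms (4 carbon, 1 oxygen; one four-membered non-aromatic ring of carbon only) in place of a group of 6 heavy atoms (6 carbon; one six-membered aromatic ring of carbon only), on a double-bonded chain carbon bound to a double-bonded chain carbon, and it made a 1.2-fold higher number from compound 2 to compound 1 (0.09 log units; within the scatter). Compound 3 `O=C(/C=C/c1ccccc1)Nc1nc2ccccc2s1` gives 646 umol/kg; its core differs from the core of compound 2 by hydrogen in place of nitro on an aromatic carbon, a step of a 1.3-fold higher number from compound 2 to compound 3 (0.12 log units; within the scatter).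

Compound 4 `O=C(/C=C/OC1=CC=C1)Nc1nc2ccccc2s1` has not yet been measured in this assay. It differs from compound 3 by a group of 5 heavy atoms (4 carbon, 1 oxygen; one four-membered non-aromatic ring of carbon only) in place of a group of 6 heavy atoms (6 carbon; one six-membered aromatic ring of carbon only), on a double-bonded chain carbon bound to a double-bonded chain carbon, which is the same change as that from compound 2 to compound 1, at the same place. Because that change on the nitro-bearing core gave a 1.2-fold higher number from compound 2 to compound 1 (0.09 log units; within the scatter), the step from compound 3 to compound 4 is expected to be of similar size, about a 1.2-fold higher number from compound 3 to compound 4 (0.08 log units; within the scatter), although with a single earlier example this expectation rests on little. Compound 4 is therefore estimated to give 780 umol/kg, most likely between 450 umol/kg and 1350 umol/kg.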

Compound 4, dose for half-maximal effect: 781 umol/kg
Compound 4: the middle estimate sits 1.0-fold (0.00 log units) below what was measured; the range from low to high includes it.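

In this assay, the group with the four-membered ring in place of phenyl, on a double-bonded chain carbon bound to a double-bonded chain carbon, gave a 1.2-fold higher number from compound 3 to compound 4 (0.08 log units; within the scatter), and this agrees with the same change on the nitro-bearing core: the same change on two cores in this assay, a 1.2-fold higher number (0.09 log units; within the scatter) from compound 2 to compound 1 and a 1.2-fold higher number (0.08 log units; within the scatter) from compound 3 to compound 4, 1.0-fold (0.01 log units) apart, within the scatter of two such steps. Hydrogen in place of nitro on an aromatic carbon gave a 1.3-fold higher number from compound 1 to compound 4 (0.12 log units; within the scatter), which likewise agrees with the earlier step: the same change on two cores in this assay, a 1.3-fold higher number (0.12 log units; within the scatter) from compound 2 to compound 3 and a 1.3-fold higher number (0.12 log units; within the scatter) from compound 1 to compound 4, 1.0-fold (0.01 log units) apart, within the scatter of two such steps. Across these two cores the two changes therefore add up consistently, but every step lies within the scatter, so this shows only that neither change moved the dose measurably on either core, not that either has a real effect of its own or that the agreement would hold on a further core.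

The compounds shown leave open what an amine or a longer chain would give in place of phenyl at this place. They also leave open whether a carboxylic acid or a chlorine atom in place of nitro on the aromatic carbon would give a step beyond the scatter.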